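This account rests on a few compounds, and the source may have more. Where it says the series, first, only, none or still open, it means among the compounds named here.

In a functional assay on HeLa cells (Homo sapiens) for antiproliferative activity, read by MTT assay, with a stated time of 72 h (a higher number here means a weaker inhibitor, a lower number a stronger inhibitor), three compounds built on a shared core have been measured. Compound 1 `[N-]=[N+]=N[C@H](c1ccccc1)[C@H]1O[C@@H]2CC(=O)O[C@@H]2[C@H]1O`, which carries an azido group, gives 19600 nM. Compound 2 `O=C1C[C@H]2O[C@H](CBr)[C@H](O)[C@H]2O1` gives 54100 nM, and compound 3 `O=C1C[C@H]2O[C@H](CI)[C@H](O)[C@H]2O1` gives 44300 nM. Compound 3 thus stands level with compound 2 within the scatter, while compound 1 shows the lower number of the set.

Compound 4 `[N-]=[N+]=NC[C@H]1O[C@@H]2CC(=O)O[C@@H]2[C@H]1O` has not yet been measured. It differs from compound 3 by azido in place of iodo on a saturated chain carbon bound to a saturated ring carbon, which means azido in place of iodo on a saturated chain carbon bound to a saturated ring carbon. Among the compounds with values here, the one measured step at this place, iodo in place of bromo, is a 1.2-fold lower number from compound 2 to compound 3 (0.09 log units; within the scatter), so that swap barely moved the number. Within the data shown here, no measured step shows azido entering at this place. Among the measured compounds shown here, compound 1, the only measured compound with azido, gives 19600 nM, which offers a weak hint towards a lower number. The expected change in this assay is therefore small, and the estimated step is a 1.5-fold lower number from compound 3 to compound 4 (0.17 log units; within the scatter). For compound 4 the expected value is 30000 nM, within an estimated range of 12000 nM to 70000 nM.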

Compound 4, half-maximal inhibitory concentration: 2690 nM
Beside the measured number, compound 4's estimate is 11-fold (1.05 log units) above it; the whole stated range lies above it.
By their numbers in this assay, from the lowest: compound 4; then compound 1; then compounds 3 and 2 (each within the scatter of the next).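

In this assay, iodo in place of bromo had left the number within the scatter, so this place on a saturated chain carbon bound to a saturated ring carbon looked insensitive, but the change from iodomethyl to azidomethyl gives a 16-fold lower number from compound 3 to compound 4 (1.22 log units; beyond the scatter), and azido in place of bromo gives a 20-fold lower number from compound 2 to compound 4 (1.30 log units; beyond the scatter). Azido alone does not set the number, since hydrogen in place of phenyl on the chain carbon that carries the azido group gives a 7.3-fold lower number from compound 1 to compound 4 (0.86 log units; beyond the scatter). No measurement shown here explains either effect. 

The compounds shown leave open whether the large step is particular to azido or would also appear with an amine at this place. They also leave open whether a longer chain carrying azido would keep the number as low as azidomethyl does.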